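Three Naphthoquinone Ethers Measured, an Ester Awaits

The source may report more compounds than this note shows. Statements on the series, on what has been measured and on what is new or still open speak of the compounds shown alone.

The shared core carries a prenyl-type chain on one side and, beyond it, an oxygen on a saturated carbon that holds a variable tail. Compound 1 `CC(=O)OCCO[C@H](CC=C(C)C)C1=CC(=O)c2c(O)ccc(O)c2C1=O` carries a 2-acetoxyethyl tail there; in a functional assay on DU-145 cells (Homo sapiens) for cytotoxicity, read by MTT assay (a higher number here means a weaker inhibitor, a lower number a stronger inhibitor), compound 1 gives 15500 nM. Compound 2 `CCC(O)CO[C@H](CC=C(C)C)C1=CC(=O)c2c(O)ccc(O)c2C1=O` gives 16400 nM in this assay, and compound 3 `CCC(CO[C@H](CC=C(C)C)C1=CC(=O)c2c(O)ccc(O)c2C1=O)OC(C)=O` gives 25400 nM. Compound 1 thus has the lowest of the three numbers, yet every gap is small: a 1.1-fold higher number from compound 1 to compound 2 (0.02 log units; within the scatter), a 1.6-fold higher number from compound 1 to compound 3 (0.21 log units; within the scatter) and a 1.5-fold higher number from compound 2 to compound 3 (0.19 log units; within the scatter).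

Compound 4 `CC[C@@](C)(O)CC(=O)O[C@H](CC=C(C)C)C1=CC(=O)c2c(O)ccc(O)c2C1=O` changes the same tail more deeply: (2-hydroxy-2-methylbutyl)carbonyl in place of 2-acetoxyethyl on an oxygen on a saturated carbon. Among the compounds with values here, no measured step covers such an exchange, and the three steps known stay within the scatter, so nothing in the numbers points either way. The expected step is therefore a 1.0-fold higher number from compound 1 to compound 4 (0.01 log units; within the scatter), no more than the scatter allows. Compound 4 is estimated to give about 16000 nM in this assay, within a range from 6000 nM to 45000 nM.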

Compound 4, half-maximal inhibitory concentration: 12700 nM
Beside the measured number, compound 4's estimate is 1.3-fold (0.10 log units) above it; the measured number falls inside the stated range.
By their numbers in this assay, from the lowest: compounds 4, 1, 2 and 3 (each within the scatter of the next).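

Putting the (2-hydroxy-2-methylbutyl)carbonyl tail in place of 2-acetoxyethyl attaches a carbonyl group directly to this oxygen and adds a hydroxyl-bearing defined stereocentre, yet this assay shows no change beyond the scatter (a 1.2-fold lower number from compound 1 to compound 4 (0.09 log units; within the scatter)). Set against the two butyl-type tails, compound 4 also stays within the scatter (a 1.3-fold lower number from compound 2 to compound 4 (0.11 log units; within the scatter); a 2.0-fold lower number from compound 3 to compound 4 (0.30 log units; within the scatter)), so this position has accepted both carbonyl-linked and saturated-carbon-linked tails without a clear shift. Nothing available explains why these numbers stay so close.

On these data alone, all four tails are uncharged open chains built from carbon and oxygen, so it remains open whether an amine, a carboxylic acid or a phenyl ring here would move the number beyond the scatter. Also open, as far as these compounds go, is whether the opposite arrangement at the new stereocentre would give a different result.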